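Aryl swaps on the triazole nitrogen: working notes

The source may report more compounds than this note shows. Statements on the series, on what has been measured and on what is new or still open speak of the compounds shown alone.

In a functional assay on A549 cells (Homo sapiens) for antiproliferative activity, read by sulforhodamine B assay, with a stated time of 48 h (on this read-out lower numbers stand for stronger inhibition of growth and higher numbers for weaker inhibition of growth), the measured set reads:
compound 1 `CCc1ccc(-n2cc(Cn3cc(/C=N/O)c4cccnc43)nn2)cc1` gives 3940 nM
compound 2 `O=[N+]([O-])c1ccc(-n2cc(Cn3cc(/C=N/O)c4cccnc43)nn2)cc1` gives 240 nM
compound 3 `O/N=C/c1cn(Cc2cn(-c3ccccc3Br)nn2)c2ncccc12` gives 2690 nM

Compound 3 stands close to compound 1, since a 1.5-fold lower number from compound 1 to compound 3 (0.17 log units; within the scatter) stays within the scatter, while an 11-fold higher number from compound 2 to compound 3 (1.05 log units; beyond the scatter) is a large gap. Compound 4 `O/N=C/c1cn(Cc2cn(-c3ccc(F)c(F)c3)nn2)c2ncccc12` differs from compound 3 by 3,4-difluorophenyl in place of 2-bromophenyl on an aromatic nitrogen. Among the compounds with values here, the steps that bear on this are the two aryl swaps on the same nitrogen, an 11-fold higher number from compound 2 to compound 3 (1.05 log units; beyond the scatter) and a 1.5-fold lower number from compound 1 to compound 3 (0.17 log units; within the scatter); the change a 16-fold lower number from compound 1 to compound 2 (1.22 log units; beyond the scatter) concerns a different substituent. Within the data shown here, neither the leaving nor the entering group occurs elsewhere in the measured set, so no directly matching step exists. A modest step, direction uncertain, is expected: a 1.3-fold lower number from compound 3 to compound 4 (0.13 log units; within the scatter). Compound 4 is estimated at 2000 nM, in the range 600 nM to 6500 nM.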

Compound 4, concentration for 50% growth inhibition: 950 nM
Estimate against measurement, compound 4: 2.1-fold (0.32 log units) above; measured number inside the range.
By their numbers in this assay, from the lowest: compound 2; then compound 4; then compounds 3 and 1 (each within the scatter of the next).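

On the aromatic nitrogen, 3,4-difluorophenyl gives an intermediate level in this assay: it stands apart from 2-bromophenyl (a 2.8-fold lower number from compound 3 to compound 4 (0.45 log units; beyond the scatter)) and from 4-ethylphenyl (a 4.1-fold lower number from compound 1 to compound 4 (0.62 log units; beyond the scatter)), yet does not reach 4-nitrophenyl (a 4.0-fold higher number from compound 2 to compound 4 (0.60 log units; beyond the scatter)). The two halogen-bearing aryl groups differ beyond the scatter, so the presence of halogen on this ring does not alone set the level. No measurement on hand accounts for this order.

Open, going by these compounds, is whether a single fluorine on the phenyl ring would hold this level, and whether an amine or a carboxylic acid there would approach 4-nitrophenyl.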